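The compounds below may be only part of what the source reports. "The series", "measured", "known", "first", "only" and "open" are said of these compounds alone.

Compound 1 `C=CC(=O)Nc1cccc(NC(=O)CSc2nc(Nc3cccc(C)c3)c3ccccc3n2)c1`: 20900 nM.
Compound 2 `C=CC(=O)Nc1cccc(NC(=O)CSc2nc(Nc3ccc(Cl)c(Cl)c3)c3ccccc3n2)c1`: reaches only the assay limit, > 50000 nM.

In a functional assay on MGC-803 cells (Homo sapiens) for inhibition, read by MTT assay, with a stated time of 72 h (on this read-out lower numbers stand for stronger inhibition and higher numbers for weaker inhibition), compound 1 gives 20900 nM. For compound 2 only a limit is known, since its result sits at the assay limit (the limit of > 50000 nM in this assay, at which 1 of the 2 values shown sits). Among the measured compounds shown here, the single measured step, an at least 2.3-fold higher number from compound 1 to compound 2 (0.37 log units; beyond the scatter), goes toward weaker inhibition. Compound 3 `C=CC(=O)Nc1cccc(NC(=O)CSc2nc(Nc3ccc(Cl)cc3Cl)c3ccccc3n2)c1` keeps the same atoms, with 2,4-dichlorophenyl in place of 3,4-dichlorophenyl on a nitrogen on an aromatic ring. For the measured compounds named here, no measured step compares these two dichlorophenyl arrangements, so no step beyond the scatter is expected, and the expected step is a step that the limit leaves unreadable from compound 2 to compound 3. Compound 3 is therefore estimated at 60000 nM, most likely between 20000 nM and 180000 nM.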

Compound 3, half-maximal inhibitory concentration: 12100 nM
Estimate against measurement, compound 3: 5.0-fold (0.70 log units) above, and the stated range ends above it.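

On this nitrogen, the arrangement of the two chlorines matters and not only their presence, since the same atoms give an at least 4.1-fold lower number from compound 2 to compound 3 (0.61 log units; beyond the scatter). That step has only a minimum size because compound 2 reached a limit, not a measured number: the limit of > 50000 nM in this assay, at which 1 of the 3 values shown sits. The 2,4-dichlorophenyl group also holds up against the 3-methylphenyl group, with a 1.7-fold lower number from compound 1 to compound 3 (0.24 log units; within the scatter), so two chlorines on this ring do not by themselves weaken inhibition.

Still open, from the compounds shown here alone, is how a phenyl ring carrying one chlorine, or a methoxy group, would compare on this nitrogen.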